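The source may report more compounds than this note shows. Statements on the series, on what has been measured and on what is new or still open speak of the compounds shown alone.

In a functional assay on HL-60 cells (Homo sapiens), read by calcium flux (on this read-out higher numbers stand for an effect only at larger amounts of compound and lower numbers for an effect already at smaller amounts), compound 1 (`COc1cccc(Cc2cc(C(C)C)nn(CC(=O)Nc3ccc(Br)cc3)c2=O)c1`) gives > 50000 nM, a limit of the assay and not a number. Compound 2 (`Cc1cc(Cc2cccc(Cl)c2)c(=O)n(CC(=O)Nc2ccc(Br)cc2)n1`) gives > 50000 nM, also a limit, so it has no numerical position, and the limit of > 50000 nM in this assay, at which 2 of the 2 values shown sit, holds for both compounds. Compound 3 (`Cc1cc(Cc2cccs2)c(=O)n(CC(=O)Nc2ccc(Br)cc2)n1`) has thiophen-2-yl in place of 3-chlorophenyl on a saturated chain carbon bound to an aromatic carbon. Going by the values given here, no measured step shows what this change does in this assay. The expected step, an at least 1.2-fold lower number from compound 2 to compound 3 (0.09 log units; that floor lies within the scatter), is estimated to stay within the scatter, in neither direction. Compound 3 is expected at 40000 nM, with an estimated range of 10000 nM to 80000 nM.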

Compound 3, half-maximal effective concentration: > 50000 nM
Compound 3 ended at the assay's limit (the forecaster's own chance of this, stated with the estimate: 75%); middle value at least 1.2-fold (0.09 log units) from the limit.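

The values of compound 2 and compound 3 in this assay are both limits of the assay, so no step can be read between them: the limit of > 50000 nM in this assay, at which 3 of the 3 values shown sit.

The compounds shown leave open whether thiophen-2-yl and 3-chlorophenyl differ at all in this assay.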